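Butoxy in place of methoxy on the shared core

A few compounds are considered here, and "the series" means these few. Any claim that something is new, unique, unknown or untested is made for them only; others in the source may bear on it.

compound 1 `CCCCOc1ccc2[nH]c(-c3ccccc3)c(C3=C(Br)C(=O)NC3=O)c2c1`: 3.42
compound 2 `CCCCOc1ccc2[nH]c(-c3ccc(OC)cc3)c(C3=C(Br)C(=O)NC3=O)c2c1`: 3.43
compound 3 `COc1cccc(-c2[nH]c3ccc(OC)cc3c2C2=C(Br)C(=O)NC2=O)c1`: 2.79

In a physicochemical assay for lipophilicity (on this read-out lower numbers stand for lower lipophilicity and higher numbers for higher lipophilicity), compound 3 stands lowest of the three, beyond the scatter from both compound 1 and compound 2. Compound 4 `CCCCOc1ccc2[nH]c(-c3cccc(OC)c3)c(C3=C(Br)C(=O)NC3=O)c2c1` differs from compound 3 by propyl in place of hydrogen on a saturated chain carbon bound to an oxygen on an aromatic ring, so the methoxy of compound 3 becomes a butoxy. Among the measured compounds shown here, no measured step covers this change directly. For the measured compounds named here, the one measured step, a number 0.01 log units higher from compound 1 to compound 2 (within the scatter), concerns a methoxy on an aromatic carbon and bears little on it. Compound 1 and compound 2 both carry the butoxy and sit well above compound 3 in this assay, which is the only footing available. The step is therefore expected to be a number 0.61 log units higher from compound 3 to compound 4 (beyond the scatter). Compound 4 is estimated at 3.4, with a range of 3 to 3.8.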

Compound 4, partition coefficient: 3.46
Beside the measured number, compound 4's estimate is 0.06 log units below it; measured number inside the range.
By their numbers in this assay, from the lowest: compound 3; then compounds 1, 2 and 4 (each within the scatter of the next).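

In this assay, among the compounds shown here, methoxy to butoxy on the shared core gives the first measured step for this position, with the 3-methoxyphenyl held: a number 0.67 log units higher from compound 3 to compound 4 (beyond the scatter). With the butoxy held, 3-methoxyphenyl in place of 4-methoxyphenyl reads a number 0.03 log units higher from compound 2 to compound 4 (within the scatter), and methoxy in place of hydrogen on an aromatic carbon reads a number 0.04 log units higher from compound 1 to compound 4 (within the scatter), so neither change separates these compounds. Nothing measured accounts for the butoxy step. Open, from the compounds shown here alone, is how a propoxy or a longer chain compares at this position, and whether an amine at the chain end holds the same reading.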